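This account rests on a few compounds, and the source may have more. Where it says the series, first, only, none or still open, it means among the compounds named here.

In a functional assay on a cell-free system (plasma, Homo sapiens), with a stated time of 3 min (a higher number here means a weaker inhibitor, a lower number a stronger inhibitor), compound 1 (`CCCC[C@@H](O)C(=O)N1C[C@H]2C[C@H]2[C@H]1C(=O)NCc1cc(Cl)ccc1-n1cnnn1`) gives 750 nM and compound 2 (`O=C(NCc1cc(Cl)ccc1-n1cnnn1)[C@@H]1CCON1C(=O)[C@H](O)c1ccccc1`) gives 1500 nM, two values within the usual scatter of each other. Compound 3 (`O=C(NCc1cc(Cl)ccc1-n1cnnn1)[C@@H]1[C@@H]2C[C@@H]2CN1C(=O)[C@H](O)c1ccccc1F`) has not yet been measured. It differs from compound 1 by one change, (2-fluorophenyl in place of butyl on a saturated chain carbon bound to a carbonyl carbon and an oxygen on a saturated carbon), on a saturated chain carbon bound to a carbonyl carbon and an oxygen on a saturated carbon. Going by the values given here, no measured step covers this change, so only a moderate move towards a lower number in this assay is expected, and the uncertainty is wide. For compound 3 the estimated value is 300 nM, with an expected range of 60 nM to 1500 nM. The expected change is a 2.5-fold lower number from compound 1 to compound 3 (0.40 log units; beyond the scatter).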

Compound 3, half-maximal inhibitory concentration: 580 nM
Estimate against measurement, compound 3: 1.9-fold (0.29 log units) below; measured number inside the range.
By their numbers in this assay, from the lowest: compounds 3, 1 and 2 (each within the scatter of the next, the first and the last beyond it).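

At the saturated chain carbon bound to a carbonyl carbon and an oxygen on a saturated carbon, 2-fluorophenyl in place of butyl gives a 1.3-fold lower number from compound 1 to compound 3 (0.11 log units; within the scatter) in this assay. This position therefore holds either an open chain or an aromatic ring with no step beyond the scatter. Nothing at hand accounts for this result.

The compounds shown leave open whether an amine or a carboxylic acid on this carbon would give a step beyond the scatter. Compound 2 differs from compound 3 in more than one place, so the part played by the fluorine remains unresolved.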